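Halogen Exchange in a Sulfonylurea Series on Rat Aorta

The compounds below may be only part of what the source reports. "The series", "measured", "known", "first", "only" and "open" are said of these compounds alone.

Compound 1 `COc1ccc(F)cc1C(C)NC(=O)N(C)S(=O)(=O)c1ccc(Cl)cc1`, compound 3 `COc1ccc(Br)cc1C(C)NC(=O)N(C)S(=O)(=O)c1ccc(Cl)cc1` and compound 2 `COc1ccc(Br)cc1C(C)NC(=O)NS(=O)(=O)c1ccc(C)cc1` were examined in a functional assay on thoracic aorta (Rattus norvegicus, strain Wistar), with a stated time of 15 min; on this read-out lower numbers stand for an effect already at smaller amounts and higher numbers for an effect only at larger amounts of compound. Compound 3 gives 19100 nM. Compound 1 gives 12600 nM, and the step of a 1.5-fold lower number from compound 3 to compound 1 (0.18 log units; within the scatter) goes with fluoro in place of bromo on an aromatic carbon. For compound 2 the assay reports only a limit, > 300000 nM. Compound 2 thus sits at the limit of > 300000 nM in this assay, at which 1 of the 3 values shown sits. How the core of compound 2 differs from that of compound 3 is not broken down here.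

Compound 4 `COc1ccc(F)cc1C(C)NC(=O)NS(=O)(=O)c1ccc(C)cc1` has not yet been measured in this assay. It differs from compound 2 by fluoro in place of bromo on an aromatic carbon, the same change as that from compound 3 to compound 1. Because that change gave a 1.5-fold lower number from compound 3 to compound 1 (0.18 log units; within the scatter), compound 4 is expected to move by a step that the limit leaves unreadable from compound 2 to compound 4. Compound 4 is therefore estimated at 400000 nM, with a range from 150000 nM to 1500000 nM, and most likely the assay will again return only a limit.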

Compound 4, half-maximal effective concentration: > 300000 nM
Compound 4 ended at the assay's limit; the forecaster's own chance of this, stated with the estimate: 75%; the middle value does not contradict the limit.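

No step can be read between compound 2 and compound 4, since in this assay both stand at a limit of the assay: the limit of > 300000 nM in this assay, at which 2 of the 4 values shown sit.

The compounds shown leave open whether fluoro in place of bromo changes the read-out at all on the core of compound 2.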